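From 2,3-dimethylphenyl to 3,5-dimethylphenyl: a stability estimate

The source may report more compounds than this note shows. Statements on the series, on what has been measured and on what is new or still open speak of the compounds shown alone.

Measured so far in an ADME assay on microsomes from liver (Mus musculus) for metabolic stability, read by LC-MS, with a stated time of 1 h, tested at 5 uM (on this read-out lower numbers stand for a less stable compound and higher numbers for a more stable compound), as the share of compound left:
- compound 1 `Cc1nc(-c2ccccc2)c(C(=O)N2CCN(c3cccc(C)c3C)CC2)o1` with 83.6% remaining
- compound 2 `Cc1nc(-c2ccc(F)cc2)c(C(=O)N2CCN(c3cc(Cl)cc(Cl)c3)CC2)o1` with 31.1% remaining

Compound 1 holds the higher of these two numbers. The gap to compound 2 lies beyond the usual scatter of repeat measurements. The two compounds differ in more than one place, so no single change has yet been measured on its own.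

The next compound to test is compound 3 (`Cc1cc(C)cc(N2CCN(C(=O)c3oc(C)nc3-c3ccccc3)CC2)c1`). Its difference from compound 1 (3,5-dimethylphenyl in place of 2,3-dimethylphenyl on an amine nitrogen in a ring) is that 3,5-dimethylphenyl stands in place of 2,3-dimethylphenyl on an amine nitrogen in a ring. The two have the same atoms, joined differently.

Compound 1, at 83.6% in this assay, starts high, so it has more room to fall than to rise. The estimate is a moderate downward step (a number 15.6 percentage points lower from compound 1 to compound 3 (beyond the scatter)) that may only just clear the scatter. For compound 3 the expected value is 68% within an estimated range of 42% to 87% on this scale.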

Compound 3, percent of the compound remaining: 12%
The estimate for compound 3 lay 56 percentage points above the measured number; the measured number lies below the stated range.
By their numbers in this assay, from the lowest: compound 3; then compound 2; then compound 1.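

In this assay, this pair gives the first measured effect of a single change: a number 71.6 percentage points lower from compound 1 to compound 3 (beyond the scatter), a large step made by 3,5-dimethylphenyl in place of 2,3-dimethylphenyl on an amine nitrogen in a ring. The two compounds have the same atoms, joined differently, and the groups that swap places have the same counts of heavy atoms, rings and hydrogen-bond donors and acceptors, so at this position the arrangement of the two methyl groups on the phenyl ring is enough to change the read-out greatly, even with the composition unchanged. Nothing measured here explains why this rearrangement has such a large effect.

Going by these compounds, it remains open whether a phenyl ring with a single methyl group would stay close to compound 1 or fall close to compound 3, which would help show which part of the 2,3-dimethyl arrangement matters. On these data alone, it is also open how other groups at this position, such as methoxy or a pyridine ring, would behave on the shared core.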